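The compounds below may be only part of what the source reports. "The series", "measured", "known", "first", "only" and "open" are said of these compounds alone.

Compound 1 `C=C[S+]([O-])c1ccccc1` is the starting point of this step. For the measured compounds named here, in an assay for inhibition of alcohol dehydrogenase (Equus caballus) (on this read-out lower numbers stand for stronger inhibition and higher numbers for weaker inhibition), compound 1 gives 500000 nM, the highest of the two numbers measured so far. The nearest measured compound is compound 2 `CCCCCC[S+](C)[O-]`, which in this assay gives 47000 nM, a gap that lies beyond the usual scatter of such measurements. Compound 3 `CC[S+]([O-])c1ccccc1` has not yet been measured. It differs from compound 1 in a single place, on a sulfur whose other neighbours are an aromatic carbon and an oxygen: ethyl in place of vinyl on a sulfur. Among the measured compounds no pair differs by this change alone, so there is no direct guide to its size. The step of a 1.7-fold lower number from compound 1 to compound 3 (0.22 log units; within the scatter) is expected to be small, toward a somewhat lower number, and may well fall within the scatter. For compound 3 the expected value in this assay is 300000 nM, with a range from 80000 nM to 1000000 nM.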

Compound 3, inhibition constant: 12500000 nM
Compound 3: middle estimate off by 42-fold (1.62 log units), on the low side, outside the stated range (above it).
By their numbers in this assay, from the lowest: compound 2; then compound 1; then compound 3.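

In this assay, ethyl in place of vinyl on a sulfur gives a 25-fold higher number from compound 1 to compound 3 (1.40 log units; beyond the scatter), so inhibition weakens clearly and this position on the sulfur proves far from indifferent to the swap. The two groups have the same count of heavy atoms, both are carbon only, and neither holds a ring, so the one counted difference between them is the double bond that vinyl carries and ethyl lacks. That shows that a swap leaving the size of the group, as counted in heavy atoms, unchanged can still move this read-out well beyond the scatter, though nothing available explains why the step is this large. On these data alone, whether that double bond is itself what matters stays open. Propyl or ethynyl on the same sulfur could help to show this, and a second core would show whether the step carries over.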